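This account rests on a few compounds, and the source may have more. Where it says the series, first, only, none or still open, it means among the compounds named here.

Measured compounds:
compound 1 `Cn1nc2c(=O)n(CC3(O)CCN(Cc4ccc(-c5ccco5)cc4Cl)CC3)cnc2c1-c1ccc(CNC(=O)C(F)(F)F)cc1`: 2060 nM
compound 2 `CCNCc1ccc(-c2c3ncn(CC4(O)CCN(Cc5ccc(-c6ccco6)cc5Cl)CC4)c(=O)c3nn2C)cc1`: 15.2 nM

Both compounds were tested in an assay on isolated protein for inhibition of ubiquitin carboxyl-terminal hydrolase 7 (Homo sapiens), with stated times of 30 min and 2 h; on this read-out higher numbers stand for weaker inhibition and lower numbers for stronger inhibition. Among the measured compounds shown here, compound 2 gives the lower of the two numbers; the only neighbour is compound 1, and the step from it, a 140-fold lower number from compound 1 to compound 2 (2.13 log units; beyond the scatter), shows that the free ethylamine of compound 2 is tied to a much lower number than the trifluoroacetylated amine of compound 1.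

Compound 3 `Cn1nc2c(=O)n(CC3(O)CCN(Cc4ccc(-c5ccco5)cc4Cl)CC3)cnc2c1-c1ccc(F)cc1` has not yet been measured. Its change from compound 2 is fluoro in place of (ethylamino)methyl on an aromatic carbon. For the measured compounds named here, the one measured step that bears on this change is a 140-fold lower number from compound 1 to compound 2 (2.13 log units; beyond the scatter): altering the amine end of this side chain moved the number a long way, and compound 3 removes that side chain entirely rather than altering it. Going by the values given here, nothing among the measured compounds shows the effect of a simple fluoro at this position.

On that basis compound 3 is expected to give a markedly higher number than compound 2, a step of about a 99-fold higher number from compound 2 to compound 3 (1.99 log units; beyond the scatter). The estimate for compound 3 in this assay is 1500 nM, with a range from 300 nM to 8000 nM.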

Compound 3, half-maximal inhibitory concentration: 64.5 nM
Estimate against measurement, compound 3: 23-fold (1.37 log units) above; measured number outside the range, below it.
By their numbers in this assay, from the lowest: compound 2; then compound 3; then compound 1.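

In this assay, the (ethylamino)methyl group proves not to be essential for a low number, since putting fluoro in its place on the aromatic carbon gives only a 4.2-fold higher number from compound 2 to compound 3 (0.63 log units; beyond the scatter) and that step is modest, though beyond the scatter. The high number of compound 1 therefore reflects the (((trifluoromethyl)carbonyl)amino)methyl group itself rather than a general need for the ethylamine, as the same position carrying only fluoro gives a 32-fold lower number from compound 1 to compound 3 (1.50 log units; beyond the scatter) and this large step shows that this acylated side chain stands well above even the small fluoro. Nothing available gives a measured reason for either step.

The compounds shown leave open whether the modest advantage of compound 2 over compound 3 rests on the amine nitrogen, on the ethyl group or on the methylene link, which a plain aminomethyl, a dimethylaminomethyl or a hydroxymethyl group at this place could separate. They also leave open how a carboxylic acid, a nitrile or a bare hydrogen on this aromatic carbon would compare with fluoro.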